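Second methyl on the amidine of compound 2

The source may hold more compounds than are shown below. What is called first, only, known or untested is meant among the compounds shown, and "the series" means these compounds.

Compound 2 `C/N=C(\N)Nc1cccc(Cl)c1` is the weaker of the two measured entries. For the measured compounds named here, in an assay for binding affinity to Serotonin 3 (5-HT3) receptor (Homo sapiens), read by radioligand binding (a lower number here means a stronger inhibitor, a higher number a weaker inhibitor), compound 2 gives 450 nM, the highest of the two numbers; the only comparison is compound 1 `N=C(N)NC(=N)Nc1cc(Cl)cc(Cl)c1`, which in this assay gives 1.8 nM, a gap well beyond the scatter. Compound 1 differs from compound 2 in several places at once, so nothing about a single change can be read from that pair.

Compound 3 `C/N=C(\NC)Nc1cccc(Cl)c1` differs from compound 2 by methyl in place of hydrogen on an amine nitrogen, the same difference cut one bond further out reading amino to methylamino. Going by the values given here, no measured pair shows this change, so its size is unanchored. The expected step from compound 2 to compound 3 is a 1.4-fold lower number from compound 2 to compound 3 (0.15 log units; within the scatter), small, possibly none beyond the scatter, leaning slightly towards a lower number. Compound 3 is estimated at 320 nM, between 80 nM and 1300 nM.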

Compound 3, inhibition constant: > 10000 nM
Compound 3 ended at the assay's limit (the forecaster's own chance of this, stated with the estimate: 5%); middle value at least 31-fold (1.49 log units) away from the limit.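

For the compounds shown here, the step from hydrogen to methyl on this amine nitrogen is the first single-place change, and in this assay it gives an at least 22-fold higher number from compound 2 to compound 3 (1.34 log units; beyond the scatter). So this nitrogen, whose other neighbour is carbon with a double bond to nitrogen, is a sensitive position: one added carbon, with no ring and no net charge, is enough to take the binding number to the top of the range. The value of compound 3, > 10000 nM, is a limit of the assay and not a number: the limit of > 10000 nM in this assay, at which 1 of the 3 values shown sits.

As far as these compounds go, whether an ethyl group or a hydroxyl on this nitrogen would behave like methyl remains open. Also open, from the compounds shown here alone, is whether the same methyl would have a comparable effect on the core of compound 1.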